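Swapping one halogenated phenyl for another on the carbonyl

The source may hold more compounds than are shown below. What is called first, only, known or untested is meant among the compounds shown, and "the series" means these compounds.

Within the data shown here, compound 2 `Cc1ccc(OCC(=O)NNC(=O)c2cc3ccccc3oc2=O)c(C(=O)c2cccc(Cl)c2)c1` gives 64900 nM in a functional assay on Ehrlich cells (Mus musculus) for cytotoxicity, read by MTT assay, with a stated time of 48 h; on this read-out higher numbers stand for weaker inhibition and lower numbers for stronger inhibition; the only other measured number comes from compound 1 `COc1ccc(C(=O)c2cc(C)ccc2OCC(=O)NNC(=O)c2cc3ccccc3oc2=O)cc1`, which gives 38400 nM, and the two lie within the scatter of each other, as the step of a 1.7-fold higher number from compound 1 to compound 2 (0.23 log units; within the scatter) shows. Compound 3 `Cc1ccc(OCC(=O)NNC(=O)c2cc3ccccc3oc2=O)c(C(=O)c2ccccc2Br)c1` carries the change (2-bromophenyl in place of 3-chlorophenyl on a carbonyl carbon). Among the measured compounds shown here, the single step that bears on this, from compound 1 to compound 2, also exchanged the ring on the carbonyl carbon and stayed within the scatter, so no shift beyond the scatter is expected here, giving a 1.1-fold lower number from compound 2 to compound 3 (0.03 log units; within the scatter). Compound 3 is therefore estimated at 60000 nM, within a range from 25000 nM to 150000 nM.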

Compound 3, half-maximal inhibitory concentration: 8000 nM
Compound 3: middle estimate off by 7.5-fold (0.88 log units), on the high side, outside the stated range (below it).
By their numbers in this assay, from the lowest: compound 3; then compounds 1 and 2 (each within the scatter of the next).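

The ring on the carbonyl carbon can move this cytotoxicity read-out beyond the scatter after all: 2-bromophenyl gives an 8.1-fold lower number from compound 2 to compound 3 (0.91 log units; beyond the scatter) and a 4.8-fold lower number from compound 1 to compound 3 (0.68 log units; beyond the scatter) as the number falls, and a lower number means stronger inhibition. The exchange from compound 1 to compound 2 gave no such sign. Nothing measured here accounts for this drop. Compound 3 changes both the halogen and its place on the ring, so the two effects cannot be separated. A 2-chlorophenyl or 3-bromophenyl group would be needed to tell them apart.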